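Aryl for butyl on the five-membered ring: compound 4

A few compounds are considered here, and "the series" means these few. Any claim that something is new, unique, unknown or untested is made for them only; others in the source may bear on it.

Three compounds share one core and differ only in the group on the aromatic carbon of the five-membered aromatic ring with 3 nitrogen. Compound 1 `COc1nc2ccc(Br)cc2cc1C(c1ccccc1)n1cc(-c2ccccc2F)nn1` carries a 2-fluorophenyl there and gives 7.33% in an ADME assay on SK-OV-3 cells (Homo sapiens) for cytotoxicity, read by sulforhodamine B assay, with a stated time of 48 h, tested at 10 uM; on this read-out higher numbers stand for more inhibition at the one concentration tested (going by the name of the read-out) and lower numbers for less inhibition. Compound 2 `CCCCc1cn(C(c2ccccc2)c2cc3cc(Br)ccc3nc2OC)nn1` carries a butyl and gives 11.1% in this assay; compound 3 `COc1nc2ccc(Br)cc2cc1C(c1ccccc1)n1cc(CCCCCO)nn1` carries a 5-hydroxypentyl and gives 8.69%. Compound 2 holds the highest of the three numbers, but neither neighbour is separated from it by more than the scatter: a number 2.4 percentage points lower from compound 2 to compound 3 (within the scatter) and a number 3.8 percentage points higher from compound 1 to compound 2 (within the scatter).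

Compound 4 `COc1nc2ccc(Br)cc2cc1C(c1ccccc1)n1cc(-c2ccc(F)cc2)nn1` is not yet measured. Its change from compound 2 is 4-fluorophenyl in place of butyl on an aromatic carbon. The step that bears on it most directly is a number 3.8 percentage points higher from compound 1 to compound 2 (within the scatter), since compound 1 already carries a fluorophenyl in place of the butyl, with a fluorine at a different ring position; a number 1.4 percentage points higher from compound 1 to compound 3 (within the scatter) likewise shows the ring group and a chain giving numbers within the scatter of each other. No step beyond the scatter is therefore expected in this assay, only a number 2.6 percentage points lower from compound 2 to compound 4 (within the scatter). Compound 4 is estimated at 8.5%, with a range from 0% to 18%.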

Compound 4, a percentage reported as inhibition, at one concentration (the size of the read-out at that concentration, not a potency): 14.3%
Estimate against measurement, compound 4: 5.8 percentage points below; the range from low to high includes it.
By their numbers in this assay, from the lowest: compounds 1, 3, 2 and 4 (each within the scatter of the next).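

In this assay, for the compounds shown here, 4-fluorophenyl in place of 2-fluorophenyl on this aromatic carbon gives a number 7 percentage points higher from compound 1 to compound 4 (within the scatter) and so gives the first reading of a change in the fluorine's place on the phenyl with all else held. Against the chains, 4-fluorophenyl in place of butyl gives a number 3.2 percentage points higher from compound 2 to compound 4 (within the scatter) while 4-fluorophenyl in place of 5-hydroxypentyl gives a number 5.6 percentage points higher from compound 3 to compound 4 (within the scatter) and neither these steps nor the one between the two fluorophenyl groups separates any group tried here at this position. No measurement on hand bears on the cause of these numbers.

Still open, as far as these compounds go, is whether an amine, a carboxylic acid or an unsubstituted phenyl on this aromatic carbon would give a step beyond the scatter. From the compounds shown here alone, with readings at a single concentration only, the potency of these four compounds also remains open.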